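The source may hold more compounds than are shown below. What is called first, only, known or untested is meant among the compounds shown, and "the series" means these compounds.

Going by the values given here, in a physicochemical assay for solubility, read by HPLC, measured as thermodynamic solubility, with a stated time of 4 h, at pH 6.8 (a higher number here means a more soluble compound, a lower number a less soluble compound), compound 2 `Cn1c(COc2cccc(C(=O)O)c2)nc2ccc(Oc3cc(Cl)ccn3)cc21` gives 11 ug/mL, the lower of the two numbers measured so far; compound 1 `Cc1ccc(Oc2ccc3nc(COc4cccc(C(=O)O)c4)n(C)c3n2)cc1` gives 33 ug/mL in this assay, and the gap between them lies beyond the usual scatter. Compound 3 `Cn1c(COc2cccc(C(=O)O)c2)nc2ccc(Oc3ncc(Cl)cc3Cl)cc21` differs from compound 2 in a single place: 3,5-dichloropyridin-2-yl in place of 4-chloropyridin-2-yl on an oxygen on an aromatic ring. Among the compounds with values here, no step between measured compounds shows how such a change reads in this assay, so the expectation rests on compound 2 alone. Compound 3 is expected to give a somewhat lower number than compound 2, a step of a 2.2-fold lower number from compound 2 to compound 3 (0.34 log units; beyond the scatter) that would be beyond the scatter. Compound 3 is estimated at 5 ug/mL, with a range from 2 ug/mL to 15 ug/mL.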

Compound 3, solubility: 9.9 ug/mL
Compound 3: the middle estimate sits 2.0-fold (0.30 log units) below what was measured; low and high end bracket the measured number.
By their numbers in this assay, from the lowest: compounds 3 and 2 (each within the scatter of the next); then compound 1.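

Replacing 4-chloropyridin-2-yl with 3,5-dichloropyridin-2-yl on an oxygen on an aromatic ring reads in this assay as a 1.1-fold lower number from compound 2 to compound 3 (0.05 log units; within the scatter), the first step seen at this position. This position therefore takes this change without a shift beyond the scatter, and the two compounds cannot be ordered. Nothing available gives a cause for this reading. Going by these compounds, each chlorine's separate contribution remains open, since the step changes both their number and their placement. So does the reading with an amine or a nitrile in place of chlorine.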